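The source may report more compounds than this note shows. Statements on the series, on what has been measured and on what is new or still open speak of the compounds shown alone.

Measured compounds: compound 1 `CC(=NNC(=S)Nc1cccc(I)c1)c1ccccn1` with 84 nM in a functional assay on U-87MG ATCC cells (Homo sapiens) for cytotoxicity, read by MTT assay, with a stated time of 48 h; on this read-out lower numbers stand for stronger inhibition and higher numbers for weaker inhibition; compound 2 `C/C(=N\NC(=S)Nc1cccc(I)c1)c1ccccn1` with 84 nM; compound 3 `C/C(=N\NC(=S)Nc1cccc([N+](=O)[O-])c1)c1ccccn1` with 69 nM.

Compound 3 gives the lowest of the three numbers in this assay, though its nearest neighbour compound 1 and its furthest neighbour compound 2 both lie within the scatter of it. The next compound, compound 4 `C/C(=N/NC(=S)Nc1cccc([N+](=O)[O-])c1)c1ccccn1`, differs from compound 3 only in the drawn configuration: the two compounds have the same atoms and bonds and differ only in configuration as drawn: 1 of 1 stereo elements differ; a double bond is drawn E in compound 3 and Z in compound 4. Among the compounds with values here, the one step that touches configuration is no change at the digits printed from compound 1 to compound 2 (within the scatter), and the fact that one of compounds 1 and 2 is drawn with a defined configuration and the other without, at the place where they differ shows that a drawn configuration made no measurable difference there. The step of a 1.2-fold lower number from compound 2 to compound 3 (0.09 log units; within the scatter) is also within the scatter. Compound 4 is therefore expected to show no step beyond the scatter, a 1.1-fold higher number from compound 3 to compound 4 (0.04 log units; within the scatter). The value of compound 4 in this assay is estimated at 75 nM, within 35 nM to 160 nM.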

Compound 4, half-maximal inhibitory concentration: 69 nM
The estimate for compound 4 lay 1.1-fold (0.04 log units) above the measured number; the range from low to high includes it.
By their numbers in this assay, from the lowest: compounds 3, 4, 1 and 2 (each within the scatter of the next).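

Going from the E to the Z double bond in this assay gives no change at the digits printed from compound 3 to compound 4 (within the scatter). Within the data shown here, earlier, the only step touching configuration set a drawn double bond against an undrawn one, whereas here two defined configurations are set against each other, and the number does not separate them. Nothing but configuration can account for any difference in this pair, and none appears beyond the scatter: the fact that compounds 3 and 4 differ only in the configuration as drawn

On these data alone, whether the same holds with iodo in place of nitro stays open, since only the nitro pair has both configurations drawn. So does the outcome with an amine or a carboxylic acid on that aromatic carbon.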